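The source may hold more compounds than are shown below. What is called first, only, known or untested is meant among the compounds shown, and "the series" means these compounds.

Measured compounds:
compound 1 `O=C(O)CN1C(=O)/C(=C/c2nc3ccccc3n2Cc2ccc(F)cc2)SC1=S` gives 2620 nM
compound 2 `O=C(O)CN1C(=O)/C(=C/c2nc3ccccc3n2Cc2ccc(Cl)cc2)SC1=S` gives 5580 nM
compound 3 `Cc1ccc(Cn2c(/C=C3\SC(=S)N(CC(=O)O)C3=O)nc3cc(Cl)ccc32)cc1` gives 13700 nM

All three were tested in a functional assay on MDA-MB-231 cells (Homo sapiens) for cytotoxicity, read by MTT assay, with a stated time of 48 h; on this read-out higher numbers stand for weaker inhibition and lower numbers for stronger inhibition. Compound 2 and compound 1 differ in one place, (fluoro in place of chloro on an aromatic carbon), and this change gave a 2.1-fold lower number from compound 2 to compound 1 (0.33 log units; beyond the scatter). Compound 3 has the highest number of the three; the difference between its core and the core of compound 2 is not broken down here. Compound 4 `Cc1ccc(Cn2c(/C=C3\SC(=S)N(CC(=O)O)C3=O)nc3cc(F)ccc32)cc1` is not yet measured; it differs from compound 3 by fluoro in place of chloro on an aromatic carbon. This is the same kind of change as that from compound 2 to compound 1, but the place differs: there it sat para to a large group, here it sits on a ring that is part of a fused or bridged system of two rings, meta to a fused ring and para to a fused ring. Resting on a 2.1-fold lower number from compound 2 to compound 1 (0.33 log units; beyond the scatter), a step of similar size is expected, a 1.8-fold lower number from compound 3 to compound 4 (0.26 log units; within the scatter), so compound 4 is estimated at 7500 nM, likely between 3500 nM and 18000 nM.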

Compound 4, half-maximal inhibitory concentration: 6550 nM
Compound 4: the middle estimate sits 1.1-fold (0.06 log units) above what was measured; low and high end bracket the measured number.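

In this assay, fluoro in place of chloro on an aromatic carbon gave a 2.1-fold lower number from compound 3 to compound 4 (0.32 log units; beyond the scatter), so the change carried over to a second core with much the same size: the same change on two cores in this assay, a 2.1-fold lower number (0.33 log units; beyond the scatter) from compound 2 to compound 1 and a 2.1-fold lower number (0.32 log units; beyond the scatter) from compound 3 to compound 4, 1.0-fold (0.01 log units) apart, within the scatter of two such steps

This agreement holds even though the change sits at a different place on each core. Among the compounds shown here, still, it rests on only two pairs in one cell assay, so it shows that the step transferred between these two cores, not that it will transfer to every core, and it does not explain why the step occurs.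

On these data alone, it remains open whether a methoxy group or an amine at these places would shift the number in the same direction as fluoro.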